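This account rests on a few compounds, and the source may have more. Where it says the series, first, only, none or still open, it means among the compounds named here.

Compound 1 `CCc1cccc2c(=O)c(-c3nn[nH]n3)c[nH]c12` — in a functional assay on the whole organism (strain Sprague-Dawley) for inhibition, with Rattus norvegicus as the target (on this read-out lower numbers stand for an effect already at smaller amounts and higher numbers for an effect only at larger amounts of compound), compound 1 gives 0.312 mg/kg.
Compound 2 `CC(C)c1cccc2c(=O)c(-c3nn[nH]n3)c[nH]c12` — in this assay compound 2 gives 1.25 mg/kg.

Compound 2 carries the higher of the two numbers, the step of a 4.0-fold higher number from compound 1 to compound 2 (0.60 log units; beyond the scatter) lying beyond the scatter. Compound 3 `COc1cccc2c(=O)c(-c3nn[nH]n3)c[nH]c12` is not yet measured; it differs from compound 2 by methoxy in place of isopropyl on an aromatic carbon. Among the compounds with values here, the only step that bears on this change is a 4.0-fold higher number from compound 1 to compound 2 (0.60 log units; beyond the scatter), a modest one, and the change from isopropyl to methoxy has no measured precedent of its own. Compound 3 is therefore expected to show a 2.5-fold lower number from compound 2 to compound 3 (0.40 log units; beyond the scatter), with an estimated value of 0.5 mg/kg, ranging from 0.15 mg/kg to 2.5 mg/kg.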

Compound 3, minimum effective dose: 0.15 mg/kg
Estimate against measurement, compound 3: 3.3-fold (0.52 log units) above, and the stated range covers the measured number.
By their numbers in this assay, from the lowest: compound 3; then compound 1; then compound 2.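

In this assay, within the data shown here, this aromatic carbon, ortho to a fused ring, is not limited to the alkyl groups of the earlier compounds: methoxy brings an 8.3-fold lower number from compound 2 to compound 3 (0.92 log units; beyond the scatter) and also a 2.1-fold lower number from compound 1 to compound 3 (0.32 log units; beyond the scatter) and so gives the lowest number of the three. The change from ethyl is the smaller step, yet it still lies beyond the scatter. Nothing available explains either step.

From the compounds shown here alone, it remains open whether the oxygen itself matters, or whether ethoxy, hydroxyl or chlorine on this carbon would read alike. Going by these compounds, whether methoxy behaves the same elsewhere on this ring also remains open.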